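Trimming the hydroxyethyl from the amide of compound 2

A few compounds are considered here, and "the series" means these few. Any claim that something is new, unique, unknown or untested is made for them only; others in the source may bear on it.

Compound 1, with structure `CNC(=O)c1cccn(Cc2ccccc2)c1=O`, was measured in a physicochemical assay for solubility (a lower number here means a less soluble compound, a higher number a more soluble compound), and gave 78 ug/mL. Compound 2, with structure `CNC(=O)c1cc(C(=O)NCCO)cn(Cc2ccccc2)c1=O`, carries a (2-hydroxyethyl)carbamoyl in place of hydrogen on an aromatic carbon. In this assay compound 2 is reported only as a limit of the assay, >= 140 ug/mL, so its true number is not known beyond that. This is the situation described by the limit of >= 140 ug/mL in this assay, at which 1 of the 2 values shown sits. Among the measured compounds shown here, the one measured step, an at least 1.7-fold higher number from compound 1 to compound 2 (0.25 log units; that floor lies within the scatter), therefore gives only a floor for how much that group raised the reading.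

Compound 3, with structure `CNC(=O)c1cc(C(N)=O)cn(Cc2ccccc2)c1=O`, is not yet measured. It differs from compound 2 in this way: hydrogen in place of 2-hydroxyethyl on an amide-type nitrogen. For the measured compounds named here, no measured step follows this exact change, and the single step that exists bears on it only loosely, since it concerns adding the whole carbamoyl group rather than shortening its chain. With no measured guide, the step of an at least 1.2-fold lower number from compound 2 to compound 3 (0.10 log units; that floor lies within the scatter) is expected to stay roughly within the scatter of repeated measurements. Compound 3 is therefore estimated at 110 ug/mL, with a plausible range from 45 ug/mL to 250 ug/mL.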

Compound 3, solubility: 71 ug/mL
The estimate for compound 3 lay 1.5-fold (0.19 log units) above the measured number; low and high end bracket the measured number.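

In this assay, the carbamoyl without its chain, placed on an aromatic carbon of the shared core, shows a 1.1-fold lower number from compound 1 to compound 3 (0.04 log units; within the scatter), so in this reading the bare carbamoyl cannot be told apart from the hydrogen it replaces. Cutting the 2-hydroxyethyl off the amide-type nitrogen gives an at least 1.9-fold lower number from compound 2 to compound 3 (0.29 log units; that floor lies within the scatter), which is the first look at the chain on its own, separate from the carbamoyl that carries it. The reading for compound 2 is a limit of the assay, so this step is only a floor and its true size stays unknown: the limit of >= 140 ug/mL in this assay, at which 1 of the 3 values shown sits.

The compounds shown leave open how far compound 2 truly stands from the other two, and so whether the 2-hydroxyethyl chain changes this reading by more than the scatter of repeated measurements. They also leave open how a plain ethyl without the hydroxyl, a longer chain such as 3-hydroxypropyl, or a chain ending in an amine or a carboxylic acid on the same amide-type nitrogen would compare with the hydrogen of compound 3.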